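This account rests on a few compounds, and the source may have more. Where it says the series, first, only, none or still open, it means among the compounds named here.

Of the compounds shown here, three of one series have been measured in a functional assay on HEK293 cells for antagonist activity at Orexin receptor type 2 (Homo sapiens), read by FLIPR and calcium flux; a higher number here means a more potent compound, by a factor of ten per unit of this negative logarithm, a lower number a less potent compound. Compound 3 `Cc1nc(C(=O)N2CC3(CC3)C[C@H]2CNc2ccc(Cl)cn2)c(-c2ccccc2)s1` gives 7.1. Compound 1 `Cc1cccc(NC[C@@H]2CC3(CC3)CN2C(=O)c2nc(C)sc2-c2ccccc2)n1`, in which 6-methylpyridin-2-yl stands in place of 5-chloropyridin-2-yl on an amine nitrogen (6-methylpyridin-2-yl in place of 5-chloropyridin-2-yl on an amine nitrogen), gives 7.6, a step of a number 0.50 log units higher from compound 3 to compound 1 (beyond the scatter). Compound 2 `Cc1ccc(-n2nccn2)c(C(=O)N2CC3(CC3)C[C@H]2CNc2ccc(Cl)cn2)c1` is built on a different core, and how the two cores differ is not broken down here. In this assay compound 2 gives only a limit, < 5, which is the limit of < 5 in this assay, at which 1 of the 3 values shown sits. Compound 4 `Cc1ccc(-n2nccn2)c(C(=O)N2CC3(CC3)C[C@H]2CNc2cccc(C)n2)c1` repeats the same change on the core of compound 2 (6-methylpyridin-2-yl in place of 5-chloropyridin-2-yl on an amine nitrogen). Whether the gain seen from compound 3 to compound 1 carries over to a core whose measured value is only a limit is uncertain, so the estimated step is a number no lower from compound 2 to compound 4 (the limit leaves the size open). Compound 4 is therefore expected to give about 5, most likely between 4.3 and 5.7.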

Compound 4, negative logarithm of the antagonist equilibrium constant: < 5
Compound 4 gave a limit, no number (the forecaster's own chance of this, stated with the estimate: 50%); the middle value sits exactly at the limit.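

No step can be read between compound 2 and compound 4, because both give only a limit: the limit of < 5 in this assay, at which 2 of the 4 values shown sit.

The compounds shown leave open whether 6-methylpyridin-2-yl in place of 5-chloropyridin-2-yl changes potency at all on the core of compound 2.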